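From bromo to chloro: expected cytotoxicity of compound 4

The source may report more compounds than this note shows. Statements on the series, on what has been measured and on what is new or still open speak of the compounds shown alone.

Compound 1 `O=C1N/C(=N/N=C/c2c(-c3ccc(Br)cc3)[nH]c3ccccc23)SC1CCO` is the only one of the three measured compounds whose cytotoxicity comes out as a number: in an ADME assay on BJ cells (Homo sapiens) for cytotoxicity, read by fluorescence, with a stated time of 24 h (on this read-out higher numbers stand for weaker inhibition and lower numbers for stronger inhibition), compound 1 gives 29200 nM. Compound 2 `CC1S/C(=N\N=C\c2c(-c3ccc(Br)cc3)[nH]c3ccccc23)NC1=O` reaches only the assay limit, > 50000 nM. Compound 3 `C=CCN1C(=O)C(CC(=O)c2ccc(F)cc2)S/C1=N\N=C1\CC2CCC1(C)C2(C)C` likewise stops at the limit, > 50000 nM. For the measured compounds named here, the single measured step, an at least 1.7-fold higher number from compound 1 to compound 2 (0.23 log units; that floor lies within the scatter), runs from a number to the limit of > 50000 nM in this assay, at which 2 of the 3 values shown sit, so its size is known only as a floor. Compound 4 `O=C1N/C(=N/N=C/c2c(-c3ccc(Cl)cc3)[nH]c3ccccc23)SC1CCO` differs from compound 1 by chloro in place of bromo on an aromatic carbon. Going by the values given here, no measured step touches that position; the one step known alters a different part of the molecule, and the two compounds at the limit say nothing about the bromo group. The account therefore expects no step beyond the scatter, a 1.1-fold higher number from compound 1 to compound 4 (0.05 log units; within the scatter), with a fair chance that this assay again returns only a limit for compound 4. In this assay compound 4 is expected to give 33000 nM, between 14000 nM and 75000 nM.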

Compound 4, half-maximal inhibitory concentration: 22400 nM
Compound 4: the middle estimate sits 1.5-fold (0.17 log units) above what was measured; the measured number falls inside the stated range.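

In this assay, the exchange of bromo for chloro on the aromatic carbon gives a 1.3-fold lower number from compound 1 to compound 4 (0.12 log units; within the scatter), so at this position the two halogens cannot be told apart. For the compounds shown here, compound 4 also keeps a number, which makes this the first step with a measured value at both ends, whereas the earlier step was known only as a floor: the limit of > 50000 nM in this assay, at which 2 of the 4 values shown sit. The 4-bromophenyl group is therefore not required for the measurable cytotoxicity of compound 1, as 4-chlorophenyl serves equally well in this assay.

The compounds shown leave open whether this position tolerates anything other than a halogen, such as an amine, a methoxy group or a carboxylic acid. They also leave open what plain hydrogen would give there, and whether shortening the side chain on the 4-chlorophenyl compound would again end at a limit.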